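A few compounds are considered here, and "the series" means these few. Any claim that something is new, unique, unknown or untested is made for them only; others in the source may bear on it.

The study covers four compounds built on a shared core. Compound 1 has the structure `Cc1cn([C@@H]2O[C@H](CO)[C@@H](CO)[C@@H]2O)c(=O)[nH]c1=O`, compound 2 the structure `Cc1cn([C@@H]2O[C@H](CO)[C@@H](CN)[C@@H]2O)c(=O)[nH]c1=O`, and compound 3 the structure `Cc1cn([C@H]2C[C@H](CN)[C@@H](CO)O2)c(=O)[nH]c1=O`. In a functional assay on L1210 cells (Mus musculus) for antiproliferative activity, with a stated time of 72 h (on this read-out lower numbers stand for an effect already at smaller amounts and higher numbers for an effect only at larger amounts of compound), compound 1 gives only a limit, > 100 uM. In this assay compound 2 likewise reaches only a limit, > 100 uM. Compound 3 too stops at a limit, > 100 uM. Compound 1 differs from compound 2 by hydroxy in place of amino on a saturated chain carbon bound to a saturated ring carbon, and the step it made, a step that the two limits leave unreadable from compound 2 to compound 1, cannot be sized since both ends are limits. The two cores differ by hydrogen in place of hydroxy on a saturated ring carbon, with a step that the two limits leave unreadable from compound 2 to compound 3 that is equally unreadable. Every measured value sits at the limit of > 100 uM in this assay, at which 3 of the 3 values shown sit.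

Compound 4, not yet measured, has the structure `Cc1cn([C@H]2C[C@H](CO)[C@@H](CO)O2)c(=O)[nH]c1=O` and differs from compound 3 by hydroxy in place of amino on a saturated chain carbon bound to a saturated ring carbon, the same change made from compound 2 to compound 1, at the same place. Compound 2 and compound 1 both remain at the limit of > 100 uM in this assay, at which 3 of the 3 values shown sit. On that basis compound 4 is expected to show a step that the limit leaves unreadable from compound 3 to compound 4, a step as unreadable as the earlier one. The estimate for compound 4 is 200 uM, most likely again only a limit.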

Compound 4, concentration for half-maximal effect: 50 uM
Estimate against measurement, compound 4: 4.0-fold (0.60 log units) above; the range from low to high includes it.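

In this assay, as far as these compounds go, aminomethyl to hydroxymethyl on the core of compound 3 gives an at least 2.0-fold lower number from compound 3 to compound 4 (0.30 log units; that floor lies within the scatter), so this step shows a drop in the number whose true size is unknown and whose floor cannot be told apart from scatter. The same change from compound 2 to compound 1 cannot be read, so the series shows neither that the change carries from one core to the other nor that it fails to; hydrogen in place of hydroxy on a saturated ring carbon likewise gives an at least 2.0-fold lower number from compound 1 to compound 4 (0.30 log units; that floor lies within the scatter), which shows no more than a floor of the same kind. Every one of these steps has a limit at one end or both, and none can be sized further: the limit of > 100 uM in this assay, at which 3 of the 4 values shown sit.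

The compounds shown leave open how large these steps really are, and whether the change would read the same between values that are not limits. They also leave open what a carboxylic acid or a longer chain in place of the hydroxymethyl would give on either core.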